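Halogen swap on the amine pair of the series

The source may hold more compounds than are shown below. What is called first, only, known or untested is meant among the compounds shown, and "the series" means these compounds.

Compound 1 `C=C(Br)C(=O)Nc1ccc(/C=C/C(=O)c2ccc(Cl)cc2)cc1` gives 1100 nM in a functional assay on L1210 cells (Mus musculus) for antiproliferative activity, with a stated time of 48 h; a higher number here means a weaker inhibitor, a lower number a stronger inhibitor. Compound 2 `C=C(Br)C(=O)Nc1ccc(/C=C/C(=O)c2ccc(Br)cc2)cc1` gives 620 nM in this assay. The change between them, (bromo in place of chloro on an aromatic carbon), made a 1.8-fold lower number from compound 1 to compound 2 (0.25 log units; within the scatter). Compound 3 `Nc1ccc(/C=C/C(=O)c2ccc(Cl)cc2)cc1` gives 111000 nM in this assay; its core differs from the core of compound 1 by hydrogen in place of (1-bromoethenyl)carbonyl on a nitrogen on an aromatic ring, and that step was a 100-fold higher number from compound 1 to compound 3 (2.00 log units; beyond the scatter). Compound 4 `Nc1ccc(/C=C/C(=O)c2ccc(Br)cc2)cc1` has not yet been measured. Going by the values given here, it differs from compound 3 by bromo in place of chloro on an aromatic carbon, the same change as the one from compound 1 to compound 2, made at the same place. Among the compounds with values here, for compound 4 the step in this assay is expected at a 1.6-fold lower number from compound 3 to compound 4 (0.20 log units; within the scatter), resting on the single measured instance of this change, a 1.8-fold lower number from compound 1 to compound 2 (0.25 log units; within the scatter), which stayed within the scatter. Compound 4 is therefore estimated at 70000 nM, between 30000 nM and 160000 nM.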

Compound 4, half-maximal inhibitory concentration: 90000 nM
Estimate against measurement, compound 4: 1.3-fold (0.11 log units) below; the measured number falls inside the stated range.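

In this assay, bromo in place of chloro on an aromatic carbon gives a 1.2-fold lower number from compound 3 to compound 4 (0.09 log units; within the scatter), in line with the step on the other core: the same change on two cores in this assay, a 1.8-fold lower number (0.25 log units; within the scatter) from compound 1 to compound 2 and a 1.2-fold lower number (0.09 log units; within the scatter) from compound 3 to compound 4, 1.4-fold (0.16 log units) apart, within the scatter of two such steps
Removing the (1-bromoethenyl)carbonyl from the nitrogen gives a 150-fold higher number from compound 2 to compound 4 (2.16 log units; beyond the scatter), so the large rise in the number holds with either halogen: the same change on two cores in this assay, a 100-fold higher number (2.00 log units; beyond the scatter) from compound 1 to compound 3 and a 150-fold higher number (2.16 log units; beyond the scatter) from compound 2 to compound 4, 1.4-fold (0.16 log units) apart, within the scatter of two such steps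
Going by these compounds alone, these are only two matched pairs per change, and since both halogen steps stay within the scatter, they show no core dependence but do not establish that either change would transfer to a different core.

Open, as far as these compounds go, is how a plain acetyl or an unsubstituted propenoyl on that nitrogen would compare with the (1-bromoethenyl)carbonyl. Also open, from the compounds shown here alone, is how fluoro or methoxy would behave in place of the halogen.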